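Methylation of the Phenol in an Aryl Pyrazole Urea Series

The source may hold more compounds than are shown below. What is called first, only, known or untested is meant among the compounds shown, and "the series" means these compounds.

The study compares two measured compounds in a functional assay on MDA-MB-231 cells (Homo sapiens) for inhibition, read by sulforhodamine B assay, with a stated time of 48 h, tested at 10 uM; on this read-out lower numbers stand for a stronger effect and higher numbers for a weaker effect at the one concentration tested. Compound 1, `COc1cc(Cl)cc(-c2nn(-c3cccc(NC(=O)c4cccc(C(F)(F)F)c4)c3)cc2-c2ccncc2)c1`, gives 21.4%. Compound 2, `O=C(Nc1cccc(-n2cc(-c3ccncc3)c(-c3cc(O)cc(Cl)c3)n2)c1)Nc1ccc(Cl)c(Cl)c1`, gives -38.1%, the lower of the two numbers; the gap between them lies beyond the usual scatter. Compound 1 and compound 2 differ in more than one place. No single change is tied to that gap.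

Compound 3, `COc1cc(Cl)cc(-c2nn(-c3cccc(NC(=O)Nc4ccc(Cl)c(Cl)c4)c3)cc2-c2ccncc2)c1`, differs from compound 2 in one way: methyl in place of hydrogen on an oxygen on an aromatic ring. Compound 1 also carries the methoxy group, but its weaker result cannot be pinned on that group alone. For the measured compounds named here, with no single-change step available to guide the size, the author expects the move from compound 2 to compound 3 to be a small one, a number 13.1 percentage points higher from compound 2 to compound 3 (beyond the scatter), roughly within the scatter or slightly towards weaker activity. On that basis compound 3 is estimated to reach -25%, within a range from -55% to 10%.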

Compound 3, a percentage reported as activity, at one concentration (the size of the read-out at that concentration, not a potency): -21%
For compound 3 the middle estimate is 4 percentage points below the measured one; the measured number falls inside the stated range.
By their numbers in this assay, from the lowest: compound 2; then compound 3; then compound 1.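

In this assay the step of a number 17.1 percentage points higher from compound 2 to compound 3 (beyond the scatter) comes from methyl in place of hydrogen on the oxygen, so hydroxy to methoxy at this position costs only a modest amount and compound 3 still gives a negative number. With the methoxy group present on both sides, the step of a number 42.4 percentage points lower from compound 1 to compound 3 (beyond the scatter) comes from (3,4-dichlorophenyl)amino in place of 3-(trifluoromethyl)phenyl on the carbonyl carbon, and this large step shows that the methoxy group alone does not account for the weaker result of compound 1. Nothing in the data given explains either step.

Still open, as far as these compounds go, is how a longer chain on that oxygen, or an amine in place of the hydroxy group, would read out. Also open, from the compounds shown here alone, is how the hydroxy group behaves alongside the 3-(trifluoromethyl)phenyl group on the carbonyl carbon.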